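The compounds below may be only part of what the source reports. "The series", "measured", "known", "first", "only" and "open" are said of these compounds alone.

Working notes on the series in an ADME assay on PC-3 cells (Homo sapiens) for cytotoxicity, read by sulforhodamine B assay, with a stated time of 48 h, tested at 10 uM; on this read-out higher numbers stand for more inhibition at the one concentration tested (going by the name of the read-out) and lower numbers for less inhibition.

Three members of the series have been measured. Compound 1 `COc1nc2ccc(Br)cc2cc1C(c1ccccc1)n1cc(-c2ccc(Br)cc2)nn1` gives 7.43%. Compound 2 `CCCCc1cn(C(c2ccccc2)c2cc3cc(Br)ccc3nc2OC)nn1` gives 5.54%. Compound 3 `COc1nc2ccc(Br)cc2cc1C(c1ccccc1)n1cc(-c2ccccc2F)nn1` gives 13.4%. Compound 2 stands at the low end of the three numbers, but the steps to its neighbours, a number 1.9 percentage points lower from compound 1 to compound 2 (within the scatter) and a number 7.9 percentage points higher from compound 2 to compound 3 (within the scatter), both lie within the scatter, as does a number 6 percentage points higher from compound 1 to compound 3 (within the scatter). All three substituents on the aromatic carbon of the shared core therefore read alike within the noise of this assay.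

Compound 4 `COc1nc2ccc(Br)cc2cc1C(c1ccccc1)n1cc(CO)nn1` is not yet measured. It differs from compound 2 by hydroxy in place of propyl on a saturated chain carbon bound to an aromatic carbon. Among the compounds with values here, no measured step puts a hydroxy group at this place; the steps that bear on it are the exchanges of the group on the aromatic carbon, a number 1.9 percentage points lower from compound 1 to compound 2 (within the scatter) and a number 7.9 percentage points higher from compound 2 to compound 3 (within the scatter), none of which moved the read-out beyond the scatter. The expected step is therefore a number 1.5 percentage points higher from compound 2 to compound 4 (within the scatter), none beyond the scatter. For compound 4 the estimate is 7%, with a range from 0% to 18%.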

Compound 4, a percentage reported as inhibition, at one concentration (the size of the read-out at that concentration, not a potency): 4.65%
Estimate against measurement, compound 4: 2.4 percentage points above, and the stated range covers the measured number.
By their numbers in this assay, from the lowest: compounds 4, 2, 1 and 3 (each within the scatter of the next).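

In this assay, within the data shown here, the hydroxymethyl group is the first group at this place to carry a hydrogen-bond donor and acceptor, yet with a number 0.9 percentage points lower from compound 2 to compound 4 (within the scatter) it reads alike with the butyl group. The comparison with the two aryl groups gives the same picture, with a number 2.8 percentage points lower from compound 1 to compound 4 (within the scatter) and a number 8.8 percentage points lower from compound 3 to compound 4 (within the scatter) both printed as within the scatter, so the four groups at this place of the shared core cannot be told apart at the one concentration tested. Nothing at hand explains this flat reading.

From the compounds shown here alone, whether an amine, a carboxylic acid or a longer chain at this place would move the read-out beyond the scatter stays open. Also open, going by these compounds, is whether any change elsewhere on the shared core would do so, as all four compounds keep the rest of it the same.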